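Phenyl for methyl on the amide carbonyl

A few compounds are considered here, and "the series" means these few. Any claim that something is new, unique, unknown or untested is made for them only; others in the source may bear on it.

Compound 1 `O=C(COc1ccccc1)Nc1nnc(-c2ccc(O)c(O)c2)s1`: 51300 nM
Compound 2 `CC(=O)Nc1nnc(-c2ccc(O)c(O)c2)s1`: 125000 nM

Among the measured compounds shown here, in a functional assay on HeLa cells (Homo sapiens) for cytotoxicity, read by MTT assay, with a stated time of 72 h (on this read-out lower numbers stand for stronger inhibition and higher numbers for weaker inhibition), compound 2, at 125000 nM, has the higher of the two numbers measured so far. Compound 3 `O=C(Nc1nnc(-c2ccc(O)c(O)c2)s1)c1ccccc1` has not yet been measured. It differs from compound 2 by phenyl in place of methyl on a carbonyl carbon. For the measured compounds named here, only one measured step bears on this change: a 2.4-fold higher number from compound 1 to compound 2 (0.39 log units; beyond the scatter), a modest step beyond the scatter, in which phenoxy is lost from a saturated chain carbon. Phenoxy is not phenyl and sits elsewhere, so this is only a loose guide. On that single comparison, a modest move toward a lower number is expected, estimated as a 1.9-fold lower number from compound 2 to compound 3 (0.28 log units; within the scatter). Compound 3 is expected at 65000 nM, with an estimated range of 25000 nM to 150000 nM.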

Compound 3, half-maximal inhibitory concentration: 23300 nM
The estimate for compound 3 lay 2.8-fold (0.45 log units) above the measured number; measured number outside the range, below it.
By their numbers in this assay, from the lowest: compound 3; then compound 1; then compound 2.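

In this assay, the carbonyl carbon proves to tolerate an aromatic ring attached directly: phenyl in place of methyl gives a 5.4-fold lower number from compound 2 to compound 3 (0.73 log units; beyond the scatter) and is a larger step than the earlier change at the saturated chain carbon had suggested. Phenyl in place of phenoxymethyl on the same carbon gives a 2.2-fold lower number from compound 1 to compound 3 (0.34 log units; beyond the scatter), so the ring does not need the chain and its oxygen for a lower number here, and compound 3 stands lowest of the three, with both of its steps beyond the scatter. No measurement shown accounts for either step.

The compounds leave open whether the aromatic ring itself matters or only the size of the group, which a cyclohexyl ring on this carbonyl carbon would separate. They also leave open how a pyridine ring, a chloro-substituted phenyl or a longer chain ending in an amine would behave there.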